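Amine Chain Variation on a Dicyanopyrazine Scaffold

The source may report more compounds than this note shows. Statements on the series, on what has been measured and on what is new or still open speak of the compounds shown alone.

The series is described by a functional assay on cells (Homo sapiens) for antiproliferative activity, read by MTT assay, with a stated time of 48 h; on this read-out lower numbers stand for stronger inhibition and higher numbers for weaker inhibition. Compound 1 `CN(C)CCn1c(N)c(-c2nc3ccccc3[nH]2)c2nc(C#N)c(C#N)nc21` gives 43500 nM in this assay, and compound 2 `CCN(CC)CCn1c(N)c(-c2nc3ccccc3[nH]2)c2nc(C#N)c(C#N)nc21` gives 25400 nM. The change between them, (diethylamino in place of dimethylamino on a saturated chain carbon, two bonds along the chain from an aromatic nitrogen), produced a 1.7-fold lower number from compound 1 to compound 2 (0.23 log units; within the scatter). Compound 3 `CN(C)CCCCn1c(N)c(-c2nc3ccccc3o2)c2nc(C#N)c(C#N)nc21` gives 6130 nM, the lowest number of the three; its steps to compound 2 and to compound 1 both lie beyond the scatter. The difference between the core of compound 1 and the core of compound 3 is not broken down here.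

Compound 4 `CCN(CC)CCCCn1c(N)c(-c2nc3ccccc3o2)c2nc(C#N)c(C#N)nc21` has not yet been measured. It differs from compound 3 by diethylamino in place of dimethylamino on a saturated chain carbon, four bonds along the chain from an aromatic nitrogen. This is the same kind of change as that from compound 1 to compound 2, though the place is not the same: there the amine sat two bonds along the chain from an aromatic nitrogen, here it sits four bonds along the chain. The expected step, a 1.6-fold lower number from compound 3 to compound 4 (0.21 log units; within the scatter), is taken to be of about the size of a 1.7-fold lower number from compound 1 to compound 2 (0.23 log units; within the scatter), and rests on that single measured pair alone. Compound 4 is therefore expected to give 3800 nM, estimated between 1500 nM and 9000 nM.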

Compound 4, half-maximal inhibitory concentration: 2710 nM
Compound 4: middle estimate off by 1.4-fold (0.15 log units), on the high side; low and high end bracket the measured number.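

In this assay the change to diethylamino gives a 2.3-fold lower number from compound 3 to compound 4 (0.35 log units; beyond the scatter), and set beside the earlier step, it carries over from one core to the other with no difference that can be told apart: the same change on two cores in this assay, a 1.7-fold lower number (0.23 log units; within the scatter) from compound 1 to compound 2 and a 2.3-fold lower number (0.35 log units; beyond the scatter) from compound 3 to compound 4, 1.3-fold (0.12 log units) apart, within the scatter of two such steps The step clears the scatter only on the core of compound 3, but the gap between the two steps does not, so the change can be said to carry over, not to be larger on that core. This rests on two pairs alone, which differ both in the core and in where the amine sits, four bonds along the chain in one pair and two in the other, so it shows no general rule and cannot separate those two differences.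

The compounds shown leave open whether a ring amine such as piperidine or morpholine would follow the step from dimethylamino to diethylamino. They also leave open how the same change would read on a 3-(dimethylamino)propyl chain, or with both chain lengths on one core.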